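Cyclohexyl to cyclopropylmethyl change, tracked across two cores

The compounds below may be only part of what the source reports. "The series", "measured", "known", "first", "only" and "open" are said of these compounds alone.

Compound 1 `CC1=C(C(=O)OC2CCCCC2)C(c2cccs2)NC(=O)N1` gives 7% in an assay on membranes from CHO cells for displacement of a labelled ligand from adenosine receptor A1 (Homo sapiens), read by scintillation counting, with a stated time of 60 min, tested at 1 uM; on this read-out lower numbers stand for less inhibition and higher numbers for more inhibition at the one concentration tested (going by the name of the read-out). Compound 2 `CC1=C(C(=O)OCC2CC2)C(c2cccs2)NC(=O)N1` differs by cyclopropylmethyl in place of cyclohexyl on an oxygen next to a carbonyl group and gives 23% in this assay, so that a number 16 percentage points higher from compound 1 to compound 2 (beyond the scatter). Compound 3 `CC1=C(C(=O)OC2CCCCC2)C(c2ccsc2)NC(=O)N1` differs from compound 1 by thiophen-3-yl in place of thiophen-2-yl on a saturated ring carbon; in this assay compound 3 gives 8%, and a number 1 percentage points higher from compound 1 to compound 3 (within the scatter). Compound 4 `CC1=C(C(=O)OCC2CC2)C(c2ccsc2)NC(=O)N1` is not yet measured; it differs from compound 3 by cyclopropylmethyl in place of cyclohexyl on an oxygen next to a carbonyl group, the same change that is made from compound 1 to compound 2, occurring twice among these compounds, at the same place word for word. The step of a number 15 percentage points higher from compound 3 to compound 4 (beyond the scatter) is expected to be about as large as a number 16 percentage points higher from compound 1 to compound 2 (beyond the scatter), because the starting point of compound 3 is 8% and lies near that of compound 1. Compound 4 is thus expected to give 23% in this assay, with a range from 10% to 38%.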

Compound 4, a percentage reported as inhibition, at one concentration (the size of the read-out at that concentration, not a potency): 39%
The estimate for compound 4 lay 16 percentage points below the measured number; measured number above the stated range.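

In this assay the cyclohexyl to cyclopropylmethyl change again gives a higher number, with a number 31 percentage points higher from compound 3 to compound 4 (beyond the scatter), so its direction carries from the core of compound 1 to the core of compound 3, but its size does not: the same change on two cores in this assay, a number 16 percentage points higher (beyond the scatter) from compound 1 to compound 2 and a number 31 percentage points higher (beyond the scatter) from compound 3 to compound 4, 15 percentage points apart, beyond the scatter of two such steps. The thiophen-3-yl for thiophen-2-yl change likewise depends on the group on the oxygen, with a number 16 percentage points higher from compound 2 to compound 4 (beyond the scatter): the same change on two cores in this assay, a number 1 percentage points higher (within the scatter) from compound 1 to compound 3 and a number 16 percentage points higher (beyond the scatter) from compound 2 to compound 4, 15 percentage points apart, beyond the scatter of two such steps. The two changes are therefore not additive across these four compounds, but this single square shows neither why nor whether the same holds on other cores.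

From the compounds shown here alone, it remains open whether a longer chain such as n-butyl on the oxygen follows the same course. The same question stands for a phenyl ring in place of the thiophene.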